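A few compounds are considered here, and "the series" means these few. Any claim that something is new, unique, unknown or untested is made for them only; others in the source may bear on it.

In an assay on HEK243 cells for displacement of a labelled ligand from Neuronal acetylcholine receptor; alpha3/beta4 (Homo sapiens), read by scintillation counting, with a stated time of 5 min (a lower number here means a stronger inhibitor, a higher number a weaker inhibitor), two compounds have been measured. Compound 1, `CN1CCC[C@H]1COc1cc(O)cc(-c2ccccc2)c1`, gives 200 nM in this assay. Compound 2, `CN1CCC[C@H]1COc1cc(Br)cc([N+](=O)[O-])c1`, gives 415 nM in this assay. Of these two numbers, compound 2 holds the higher one, and its distance to compound 1 lies beyond the usual scatter of repeated measurements, so compound 2 is the weaker binder of the pair.

Compound 3, `CN1CCC[C@H]1COc1cc(-c2ccccc2)cc([N+](=O)[O-])c1`, has not yet been measured. It differs from compound 2 in one place: phenyl in place of bromo on an aromatic carbon. The nitro group of compound 2 stays where it is. Going by the values given here, no single-change step between two measured compounds exists here, so the size of this change cannot be read off directly. Compound 1 also carries a phenyl group and sits at the lower of the two measured numbers, at 200 nM, which is the only hint available. On that basis, compound 3 is expected to give about 250 nM in this assay, with a likely range from 80 nM to 800 nM. This amounts to an expected step of a 1.7-fold lower number from compound 2 to compound 3 (0.22 log units; within the scatter), a modest move toward a lower number that may well stay within the scatter.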

Compound 3, inhibition constant: 947 nM
Compound 3: the middle estimate sits 3.8-fold (0.58 log units) below what was measured, outside the stated range (above it).
By their numbers in this assay, from the lowest: compound 1; then compound 2; then compound 3.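

In this assay, phenyl in place of bromo on this aromatic carbon, with the nitro group kept, gives a 2.3-fold higher number from compound 2 to compound 3 (0.36 log units; beyond the scatter), so the added ring does not bring a stronger binder in this setting. With the phenyl group held fixed, nitro in place of hydroxy on an aromatic carbon gives a 4.7-fold higher number from compound 1 to compound 3 (0.68 log units; beyond the scatter), which shows that the low number of compound 1 cannot be credited to the phenyl group alone, since the group on the other aromatic carbon also moves the result. Nothing available here explains why either change raises the number.

From the compounds shown here alone, it remains open whether the swap between bromo and phenyl would move the number in the same direction with hydroxy in place of nitro, so these two steps cannot yet be treated as independent of each other. Going by these compounds, how this aromatic carbon would respond to other groups, such as a methyl group, an amine, a carboxylic acid or a longer carbon chain, also remains open, as does whether any of them would reach a lower number than phenyl or bromo.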